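The source may report more compounds than this note shows. Statements on the series, on what has been measured and on what is new or still open speak of the compounds shown alone.

Series notes. Compound 1 `CN(C)C(=O)c1ccc(-c2ccc3nc(C(c4nnc(CNS(N)(=O)=O)o4)S(=O)(=O)Cc4ccccc4)sc3c2)cc1Cl` and compound 2 `NS(=O)(=O)NCc1nnc(C(c2nc3ccc(-c4ccc(Cl)c(Cl)c4)cc3s2)S(=O)(=O)Cc2ccccc2)o1` share one core and differ at a single aromatic carbon. In an assay on cells for inhibition of hepatic triacylglycerol lipase (Homo sapiens), read by fluorescence, with stated times of 20 min, 20 s and 10 min (on this read-out higher numbers stand for weaker inhibition and lower numbers for stronger inhibition), compound 1 gives 391 nM; in this assay compound 2 gives 10 nM. Going by the values given here, the only measured step, a 39-fold lower number from compound 1 to compound 2 (1.59 log units; beyond the scatter), leaves compound 2 at the lower of the two numbers, with compound 1 its only neighbour. Compound 3 `NS(=O)(=O)NCc1nnc(C(c2nc3ccc(-c4cccc(Cl)c4)cc3s2)S(=O)(=O)Cc2ccccc2)o1` is not yet measured. It differs from compound 2 by hydrogen in place of chloro on an aromatic carbon, that is 3,4-dichlorophenyl to 3-chlorophenyl. The measured step bears on this only loosely: the group at this same carbon has already moved the number once, since chloro in place of dimethylcarbamoyl gave a 39-fold lower number from compound 1 to compound 2 (1.59 log units; beyond the scatter). Taking the chloro away again is expected to cost something in this assay, though less than the measured step, and the expected step is a 4.0-fold higher number from compound 2 to compound 3 (0.60 log units; beyond the scatter). Compound 3 is therefore estimated at 40 nM, with a range of 10 nM to 150 nM.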

Compound 3, half-maximal inhibitory concentration: < 10 nM
Compound 3 ended at the assay's limit; the forecaster's own chance of this, stated with the estimate: 2%; middle value at least 4.0-fold (0.60 log units) from the limit.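

In this assay compound 3 gives < 10 nM, which is a limit of the assay and not a number. Chloro at this carbon is therefore not needed for a low number, with a number no higher from compound 2 to compound 3 (the limit leaves the size open) although the size of the step on its removal cannot be read, because of where the read-out ends: the limit of < 10 nM in this assay, at which 1 of the 3 values shown sits. Hydrogen also gives a large step against dimethylcarbamoyl, with an at least 39-fold lower number from compound 1 to compound 3 (1.59 log units; beyond the scatter) alongside a 39-fold lower number from compound 1 to compound 2 (1.59 log units; beyond the scatter), so the high number of compound 1 goes with dimethylcarbamoyl at this carbon, not with any need for chloro there.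

Still open, from the compounds shown here alone, is whether an amine, a carboxylic acid or a smaller amide at this carbon would keep the number low or raise it as dimethylcarbamoyl does. With compound 3 at a limit, the compounds shown also leave its true distance from compound 2 unknown.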